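Replacing the hydroxyethoxy of compound 3 by a piperidinylmethoxy

A few compounds are considered here, and "the series" means these few. Any claim that something is new, unique, unknown or untested is made for them only; others in the source may bear on it.

In an assay on isolated protein for inhibition of cathepsin S (Homo sapiens), read by fluorescence (a higher number here means a weaker inhibitor, a lower number a stronger inhibitor), compound 3 `CNC(=O)c1c(NCC2CCC3(CCC3)CC2)nc(C#N)nc1OCCO` gives 6 nM, the lowest of the three numbers; compound 1 `CNC(=O)c1c(NCC2CCC3(CCCC3)CC2)nc(C#N)nc1OCC1CCN(C)CC1` gives 12 nM, within the scatter of compound 3, and compound 2 `CNC(=O)c1c(NCCC2CCCC2)nc(C#N)nc1OCC1CCN(C)CC1` gives 26 nM, beyond it. Compound 4 `CNC(=O)c1c(NCC2CCC3(CCC3)CC2)nc(C#N)nc1OCC1CCNCC1` differs from compound 3 by piperidin-4-yl in place of hydroxymethyl on a saturated chain carbon bound to an oxygen on an aromatic ring. Going by the values given here, the only measured single step, a 2.2-fold higher number from compound 1 to compound 2 (0.34 log units; beyond the scatter), sits on the other side of the core and does not bear on this change; compounds 1 and 3 differ in two places at once, so their values show no isolated effect of the ether. Among the compounds with values here, with no direct precedent, the step of a 1.3-fold higher number from compound 3 to compound 4 (0.12 log units; within the scatter) is expected to stay within the scatter, and compound 4 is estimated at 8 nM in this assay, between 3 nM and 25 nM.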

Compound 4, half-maximal inhibitory concentration: 5 nM
Compound 4: the middle estimate sits 1.6-fold (0.20 log units) above what was measured; measured number inside the range.
By their numbers in this assay, from the lowest: compounds 4, 3 and 1 (each within the scatter of the next, the first and the last beyond it); then compound 2.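

At the saturated chain carbon bound to an oxygen on an aromatic ring, piperidin-4-yl in place of hydroxymethyl gives a 1.2-fold lower number from compound 3 to compound 4 (0.08 log units; within the scatter) in this assay. Going by these compounds alone, this is the first isolated step at this place, and it shows that the much larger ring leaves the number indistinguishable from that of the hydroxymethyl compound. No measurement offered here explains this result. On these data alone, whether a carboxylic acid or a morpholine on the same chain would read alike remains open. So does the isolated effect of a methyl on the piperidine nitrogen, which compound 1 carries alongside a second difference.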